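The compounds below may be only part of what the source reports. "The series", "measured", "known", "first", "only" and "open" are said of these compounds alone.

Compound 1 `CCCCCCCCCCCCNC[C@@H]1OC[C@H](N)[C@H]1O`, compound 2 `CCCCCCCCNC[C@@H]1OC[C@H](N)[C@H]1O` and compound 3 `CCCCCCCCCNC[C@@H]1OC[C@H](N)[C@@H]1O` share one small ring core and carry a saturated chain of varying length on one amine nitrogen. In a functional assay on MCF7 cells (Homo sapiens) for antiproliferative activity, read by MTT assay, with a stated time of 72 h (a higher number here means a weaker inhibitor, a lower number a stronger inhibitor), compound 1 gives 12600 nM. In this assay compound 2 reaches only a limit, > 128000 nM, and no number. For compound 3 this assay gives 12500 nM, the lowest number among the two measured values, though its gap to compound 1 lies within the scatter. Within the data shown here, the one measured step, an at least 10-fold higher number from compound 1 to compound 2 (1.00 log units; beyond the scatter), shows that shortening the chain costs activity, with the limit of > 128000 nM in this assay, at which 1 of the 3 values shown sits, marking how far that loss could run.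

Compound 4 `CCCCCCCCCNC[C@@H]1OC[C@H](N)[C@H]1O` keeps the chain of compound 3 unchanged; (the two compounds have the same atoms and bonds and differ only in configuration as drawn: 1 of 3 stereo elements differ; a stereocentre at a saturated ring carbon is drawn S in compound 3 and R in compound 4). Among the measured compounds shown here, no measured step here compares two configurations, so the only guide is that compound 4 carries the configuration of compound 1 and compound 2 with a chain length between theirs. The estimate for compound 4 in this assay is therefore 30000 nM, with a range from 8000 nM to 128000 nM, which means an expected step of a 2.4-fold higher number from compound 3 to compound 4 (0.38 log units; beyond the scatter).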

Compound 4, half-maximal inhibitory concentration: 60300 nM
The estimate for compound 4 lay 2.0-fold (0.30 log units) below the measured number, within the range that was stated.
By their numbers in this assay, from the lowest: compounds 3 and 1 (each within the scatter of the next); then compound 4. At a limit, above all of these: compound 2.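

In this assay, among these compounds, the step of a 4.8-fold higher number from compound 3 to compound 4 (0.68 log units; beyond the scatter) is the first measured sign that this stereocentre at a saturated ring carbon matters, and it can be tied to the switch from S to R alone because of one fact: the fact that compounds 3 and 4 differ only in the configuration as drawn. With the R configuration held, the step of a 4.8-fold higher number from compound 1 to compound 4 (0.68 log units; beyond the scatter) gives a measured point for a shorter chain, where hydrogen stands in place of propyl on a saturated chain carbon, nine bonds along the chain from an amine nitrogen, so the earlier loss on shortening is no longer known only from a limit. The other chain step, an at least 2.1-fold lower number from compound 2 to compound 4 (0.32 log units; beyond the scatter), fits the same direction across compounds 1, 4 and 2, but compound 2 has a limit and not a number: the limit of > 128000 nM in this assay, at which 1 of the 4 values shown sits.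

From the compounds shown here alone, the S configuration appears here with only one chain, so it remains open whether the same step would appear with the chain of compound 1 or of compound 2. Going by these compounds, what a still longer chain, or a phenyl group at the end of the chain, would do in this assay also remains open.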